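The compounds below may be only part of what the source reports. "The series", "measured", "known", "first", "only" and "open" are said of these compounds alone.

Working notes on the series. Three compounds have so far been run in a functional assay on the whole organism (aorta) with Rattus norvegicus as the target; on this read-out higher numbers stand for larger maximal responses and lower numbers for smaller maximal responses. Compound 1 `O=C1C(Nc2cc(F)cc(F)c2)=CC(=O)c2ncccc21` gives 91% in this assay. Compound 2 `O=C1C(Nc2ccc(F)cc2F)=CC(=O)c2ncccc21` gives 94% in this assay. Compound 3 `O=C1C(Nc2ccc(Br)cc2)=CC(=O)c2ncccc21` gives 88% in this assay. Compound 3 stands at the lowest of the three numbers, yet both of its gaps, to compound 1 and to compound 2, lie within the usual scatter of repeated measurements, so the three maximal responses cannot be told apart. Among the measured compounds shown here, no pair of the measured compounds differs in only one place, so no single-point step has been quantified.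

The next compound, compound 4 `O=C1C(Nc2ccc(C(F)(F)F)cc2)=CC(=O)c2ncccc21`, is to be measured in this assay. It differs from compound 3 in one place: trifluoromethyl in place of bromo on an aromatic carbon. For the measured compounds named here, nothing among the measured compounds isolates the effect of exchanging a substituent at this place; what the measured compounds do show is that all three reach maximal responses close to one another. On that basis the expected step is no change at the digits printed from compound 3 to compound 4 (within the scatter), small, in no fixed direction, and not beyond the scatter. Compound 4 is accordingly estimated at 88%, with a range from 76% to 100%.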

Compound 4, largest response reached (Emax), in percent of the reference or control that the assay uses: 91%
Compound 4: the middle estimate sits 3 percentage points below what was measured, within the range that was stated.
By their numbers in this assay, from the lowest: compounds 3, 1, 4 and 2 (each within the scatter of the next).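

In this assay, among the compounds shown here, the exchange of bromo for trifluoromethyl on an aromatic carbon, para to a large group, gives the first single-place step (a number 3 percentage points higher from compound 3 to compound 4 (within the scatter)). For the compounds shown here, at this position, then, 4 heavy atoms in place of 1 leave the maximal response indistinguishable on the shared core, something the earlier compounds, with no pair differing in only one place, could not show. Nothing available here bears on why the response holds across this exchange.

The compounds shown carry only bromo and trifluoromethyl at this place among single-substituent exchanges, so the observation rests on one step; what an amine, a carboxylic acid or a longer chain would do to the maximal response there stays open. As far as these compounds go, it also stays open whether any group at this position can move the response beyond the scatter at all, or whether the flat picture simply reflects how close these two groups lie in the outcome of this one read-out.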